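The source may hold more compounds than are shown below. What is called first, only, known or untested is meant among the compounds shown, and "the series" means these compounds.

Compound 2 `COc1ccc(-c2cnc(NC(=O)c3ccccc3C#N)n2C)cc1` is known in a toxicity assay on THP-1 cells (Homo sapiens) for inhibition (on this read-out lower numbers stand for higher toxicity in this test and higher numbers for lower toxicity in this test), only by a limit: compound 2 gives > 100000 nM there, which is the limit of > 100000 nM in this assay, at which 1 of the 3 values shown sits. Compound 3 `Cn1c(-c2ccccc2)cnc1NC(=O)c1ccccc1Cl` is likewise known only by a limit, giving > 50000 nM in this assay, which is the limit of > 50000 nM in this assay, at which 1 of the 3 values shown sits. Going by the values given here, compound 1 `COc1ccc(-c2cnc(NC(=O)c3ccc(F)cc3)n2-c2ccccc2)cc1` is the single compound with a measured number, giving 8800 nM in this assay. Compound 4 `COc1ccc(C(=O)Nc2ncc(-c3ccc(OC)cc3)n2C)cc1` has not yet been tested in this assay. It differs from compound 2 by 4-methoxyphenyl in place of 2-cyanophenyl on a carbonyl carbon. Among the compounds with values here, no step between two measured compounds is available here, so the study can only expect the outcome: a shift no larger than the usual scatter, with compound 4 most likely again at the limit, a step of a number no higher from compound 2 to compound 4 (the limit leaves the size open). The estimate for compound 4 is 100000 nM, expected to fall between 30000 nM and 300000 nM.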

Compound 4, half-maximal cytotoxic concentration: > 100000 nM
Compound 4: no number, only a limit; the forecaster's own chance of this, stated with the estimate: 70%; the middle value lies on the limit itself.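

Compound 2 and compound 4 are both known only by a limit, so no step between them can be read: the limit of > 100000 nM in this assay, at which 2 of the 4 values shown sit.

The compounds shown leave open whether 4-methoxyphenyl in place of 2-cyanophenyl on a carbonyl carbon changes this toxicity read-out at all.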